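The source may hold more compounds than are shown below. What is called first, only, known or untested is meant among the compounds shown, and "the series" means these compounds.

Measured in a functional assay on A-375 cells (Homo sapiens) for antiproliferative activity, read by MTT assay, with a stated time of 72 h; on this read-out lower numbers stand for stronger inhibition and higher numbers for weaker inhibition:
- Compound 1 `COc1cccc(N2C(=O)COc3ccc(-c4cnc(OC)c(NS(=O)(=O)c5ccc(F)cc5)c4)cc32)c1`: > 40000 nM. This is a limit of the assay, not a number.
- Compound 2 `O=C1COc2ccc(-c3cccc(NS(=O)(=O)c4ccc(F)cc4)c3)cc2N1c1ccc(Cl)cc1`: 32500 nM
- Compound 3 `COc1ncc(-c2ccc3c(c2)N(c2ccc(Cl)cc2)C(=O)CO3)cc1NS(=O)(=O)c1ccc(F)cc1`: 24100 nM

Compound 2 gives 32500 nM and compound 3 gives 24100 nM, two values within the usual scatter of each other. Compound 4 `O=C1COc2ccc(-c3cccc(NS(=O)(=O)c4ccc(F)cc4)c3)cc2N1c1ccc(F)cc1` changes one atom of compound 2: fluoro in place of chloro on an aromatic carbon. That is fluoro in place of chloro on an aromatic carbon, turning 4-chlorophenyl into 4-fluorophenyl. Among the measured compounds shown here, only one measured step exists, an at least 1.6-fold lower number from compound 1 to compound 3 (0.22 log units; that floor lies within the scatter), and it places 4-chlorophenyl where 3-methoxyphenyl stood. That is a different change, so it offers only weak guidance here. The expected result is no change beyond the scatter, with an estimated 1.1-fold lower number from compound 2 to compound 4 (0.03 log units; within the scatter). For compound 4 the estimate is 30000 nM, with an expected range from 15000 nM to 50000 nM.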

Compound 4, half-maximal inhibitory concentration: > 40000 nM
Compound 4: a limit, no number (the forecaster's own chance of this, stated with the estimate: 30%); at least 1.3-fold (0.12 log units) between middle value and limit.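

In this assay, the earlier step exchanged a whole substituted phenyl group, whereas this one alters a single atom on the aromatic carbon para to a large group, giving an at least 1.2-fold higher number from compound 2 to compound 4 (0.09 log units; that floor lies within the scatter). Even so small a change yields no lower number at this position. Compound 4 gives a limit of the assay, not a number, so the true size of the step cannot be read: the limit of > 40000 nM in this assay, at which 2 of the 4 values shown sit.

Open, going by these compounds, is how a group such as an amine or a carboxylic acid on this carbon would read. Also open, on these data alone, is whether fluoro in place of chloro would read the same on compound 3.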